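This account rests on a few compounds, and the source may have more. Where it says the series, first, only, none or still open, it means among the compounds named here.

Compound 1 `O=C(CSc1nnc(Br)n1Cc1ccc(Br)c2ccccc12)NO`: 640 nM
Compound 2 `O=S(=O)(CSc1nnc(Br)n1Cc1ccc(Br)c2ccccc12)Nc1ccc(F)nc1`: 1550 nM
Compound 3 `O=S(=O)(CSc1nnc(Br)n1Cc1ccc(Br)c2ccccc12)Nc1cccnc1Br`: 280 nM

In an assay on HEK293 cells for inhibition of solute carrier family 22 member 12 (Homo sapiens) (a higher number here means a weaker inhibitor, a lower number a stronger inhibitor), compound 3 stands lowest of the three numbers; compound 1 lies nearest to it and compound 2 furthest, both beyond the scatter. Compound 4 `O=S(=O)(CSc1nnc(Br)n1Cc1ccc(Br)c2ccccc12)Nc1ccc(Br)nc1` has not been measured. It differs from compound 3 in one place: 6-bromopyridin-3-yl in place of 2-bromopyridin-3-yl on a sulfonamide nitrogen.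

For the measured compounds named here, only one measured step bears on this change, a 5.5-fold lower number from compound 2 to compound 3 (0.74 log units; beyond the scatter), and it altered two things at once, the halogen and its named place on the pyridine ring. Compound 4 keeps the bromine of compound 3 but carries it as 6-bromopyridin-3-yl, the same pattern as the 6-fluoropyridin-3-yl of compound 2 apart from the halogen. Going by the values given here, no step separates the two parts of that change, so how much of it came from the bromine and how much from the move cannot be read from these three compounds. A partial return toward the number of compound 2 is therefore the expectation, with a 2.5-fold higher number from compound 3 to compound 4 (0.40 log units; beyond the scatter). Compound 4 is estimated at 700 nM, within 250 nM to 2000 nM.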

Compound 4, half-maximal inhibitory concentration: 2200 nM
Beside the measured number, compound 4's estimate is 3.1-fold (0.50 log units) below it; measured number outside the range, above it.
By their numbers in this assay, from the lowest: compound 3; then compound 1; then compounds 2 and 4 (each within the scatter of the next).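

In this assay, moving the bromine while keeping the halogen gave a 7.9-fold higher number from compound 3 to compound 4 (0.90 log units; beyond the scatter), so 2-bromopyridin-3-yl and 6-bromopyridin-3-yl on the sulfonamide nitrogen are clearly not interchangeable. Bromo in place of fluoro on an aromatic carbon gave only a 1.4-fold higher number from compound 2 to compound 4 (0.15 log units; within the scatter), which means that the earlier step, a 5.5-fold lower number from compound 2 to compound 3 (0.74 log units; beyond the scatter), can now be traced to the place of the halogen on the pyridine ring and not to the halogen itself. Nothing available here accounts for the difference between the two placements.

On these data alone, it remains open whether 2-chloropyridin-3-yl or 2-methylpyridin-3-yl would hold the number of compound 3, or whether the bromine matters at all. Unsubstituted pyridin-3-yl and plain phenyl on the same sulfonamide nitrogen would address that question.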